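The compounds below may be only part of what the source reports. "The series", "measured", "known", "first", "only" and "open" are said of these compounds alone.

Compound 3 `N/C(=N/NC(CC(=O)c1ccc(-n2ccnc2)cc1)c1ccccc1Br)c1ccccn1` belongs to a small set of three analogues that share one core and differ only in the aryl group on a saturated chain carbon bound to an amine nitrogen and a saturated chain carbon. In an ADME assay on Vero cells (Chlorocebus sabaeus) for cytotoxicity, read by MTT assay, with a stated time of 72 h (on this read-out lower numbers stand for higher toxicity in this test and higher numbers for lower toxicity in this test), compound 3 gives 29000 nM. Compound 1 `N/C(=N/NC(CC(=O)c1ccc(-n2ccnc2)cc1)c1ccccc1Cl)c1ccccn1` gives 53200 nM in this assay, and compound 2 `N/C(=N/NC(CC(=O)c1ccc(-n2ccnc2)cc1)c1cccc(Br)c1)c1ccccn1` gives 51300 nM. Compound 3 thus has the lowest of the three numbers, but its separation from the others is small: the step of a 1.8-fold lower number from compound 1 to compound 3 (0.26 log units; within the scatter) and the step of a 1.8-fold lower number from compound 2 to compound 3 (0.25 log units; within the scatter) both stay inside the scatter, as does a 1.0-fold lower number from compound 1 to compound 2 (0.02 log units; within the scatter).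

Compound 4 `N/C(=N/NC(CC(=O)c1ccc(-n2ccnc2)cc1)c1ccc([N+](=O)[O-])cc1)c1ccccn1` has not yet been measured in this assay. It differs from compound 3 in one place: 4-nitrophenyl in place of 2-bromophenyl on a saturated chain carbon bound to an amine nitrogen and a saturated chain carbon. For the measured compounds named here, no measured step exchanges a halogen for a nitro group, so the three existing steps bear on the change only indirectly, and each of them, whether a halogen swap or a shift of the halogen around the ring, left the number within the scatter. On that basis compound 4 is expected to sit close to compound 3, with a step of a 1.4-fold higher number from compound 3 to compound 4 (0.14 log units; within the scatter) that is not expected to exceed the scatter. The estimate for compound 4 in this assay is 40000 nM, with a range from 18000 nM to 90000 nM.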

Compound 4, half-maximal cytotoxic concentration: 23100 nM
Compound 4: the middle estimate sits 1.7-fold (0.24 log units) above what was measured; low and high end bracket the measured number.
By their numbers in this assay, from the lowest: compounds 4, 3, 2 and 1 (each within the scatter of the next, the first and the last beyond it).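

In this assay, 4-nitrophenyl in place of 2-bromophenyl on this saturated chain carbon gives a 1.3-fold lower number from compound 3 to compound 4 (0.10 log units; within the scatter) and so cannot be told apart from the bromo analogue, while the same group measured against the other two aryl groups gives a 2.2-fold lower number from compound 2 to compound 4 (0.35 log units; beyond the scatter) and a 2.3-fold lower number from compound 1 to compound 4 (0.36 log units; beyond the scatter). For the compounds shown here, these two modest steps are the first in the set to pass beyond the scatter, showing that the number at this position can shift measurably with the aryl group, though only when compound 4 is set against compound 1 or compound 2 and not against compound 3. Nothing shown here gives a measured reason for these differences.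

The compounds shown leave open whether the two larger steps belong to the nitro group itself or to where it stands on the ring, a question that a 4-bromophenyl or a 2-nitrophenyl analogue would address. They also leave open how this assay would respond to a quite different group at this position, such as a 4-aminophenyl or a 4-carboxyphenyl group, or to an unsubstituted phenyl ring.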